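The source may hold more compounds than are shown below. What is called first, only, known or untested is meant among the compounds shown, and "the series" means these compounds.

Compound 1, `O=C(Nc1nc2ccc(Br)cc2s1)Nc1ccc(C(F)(F)F)cc1Cl`. In a functional assay (thoracic aorta, Rattus norvegicus, strain Wistar) (on this read-out higher numbers stand for an effect only at larger amounts of compound and lower numbers for an effect already at smaller amounts), compound 1 gives > 100000 nM, which is a limit of the assay rather than a number.
Compound 2, `CC(C)NC(=O)Nc1nc2ccccc2s1`. In this assay compound 2 gives 35500 nM.
Compound 3, `Cc1ccc2nc(NC(=S)NC3CCCCC3)sc2c1`. In this assay compound 3 gives 52100 nM.

Among the two numbers reported, compound 3 holds the higher one, yet its distance from compound 2 lies within the usual scatter of this assay, so the two values are treated as alike. Compound 1 stands apart only in that its result is the assay limit (the limit of > 100000 nM in this assay, at which 1 of the 3 values shown sits).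

The next compound, compound 4, `Cc1ccc2nc(NC(=S)NCc3ccccc3)sc2c1`, is not yet measured. It differs from compound 3 in one place: benzyl in place of cyclohexyl on an amide-type nitrogen. Within the data shown here, no pair of measured compounds shows this change, so there is no measured step to lean on. From the closeness of compound 2 and compound 3, both of which keep the urea- or thiourea-type core with a varied group on the amide-type nitrogen, the step from compound 3 to compound 4 is expected to stay within the scatter, in either direction, that is a 1.2-fold lower number from compound 3 to compound 4 (0.06 log units; within the scatter).

Compound 4 is therefore estimated at 45000 nM in this assay, with an expected range from 15000 nM to 140000 nM.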

Compound 4, half-maximal effective concentration: > 100000 nM
Compound 4: a limit, no number (the forecaster's own chance of this, stated with the estimate: 30%); middle value at least 2.2-fold (0.34 log units) away from the limit.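

Among these compounds, this is the first measured step at this position: in this assay, benzyl in place of cyclohexyl on the amide-type nitrogen gives an at least 1.9-fold higher number from compound 3 to compound 4 (0.28 log units; that floor lies within the scatter). From the compounds shown here alone, only a floor for this change can be read, so its true size stays unknown, but this single change takes the compound from a number to a limit. Compound 4 gives a limit of the assay rather than a number: the limit of > 100000 nM in this assay, at which 2 of the 4 values shown sit.

The compounds shown leave open whether the aromatic ring of benzyl or its methylene goes with this result. Phenyl or cyclohexylmethyl on the same nitrogen would separate the two, and a longer chain such as n-hexyl would show whether a ring is needed there at all.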